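A few compounds are considered here, and "the series" means these few. Any claim that something is new, unique, unknown or untested is made for them only; others in the source may bear on it.

Measured compounds in a functional assay on DLD-1 cells (Homo sapiens) for cytotoxicity, read by MTT assay, with a stated time of 48 h; on this read-out lower numbers stand for stronger inhibition and higher numbers for weaker inhibition:
compound 1 `Cc1ccc(-c2cn(/N=C/c3cc4ccccc4nc3Cl)c(N)n2)cc1` — > 50000 nM
compound 2 `Nc1nc(-c2ccc(Cl)cc2)cn1/N=C/c1cc2ccccc2nc1Cl` — > 50000 nM
compound 3 `Nc1nc(-c2ccc(Br)cc2)cn1/N=C/c1cc2ccccc2nc1Cl` — 23900 nM

Compound 1 gives only a limit of the assay in this assay, > 50000 nM. Compound 2 likewise gives only a limit, > 50000 nM, so where it stands among the three values cannot be fixed more closely than that; (the limit of > 50000 nM in this assay, at which 2 of the 3 values shown sit). Within the data shown here, compound 3 is the one compound with a number, and the step of an at least 2.0-fold lower number from compound 2 to compound 3 (0.32 log units; beyond the scatter) as well as the step of an at least 2.0-fold lower number from compound 1 to compound 3 (0.32 log units; beyond the scatter) both lie beyond the scatter, whereas the step that the two limits leave unreadable from compound 1 to compound 2 cannot be read between the two limits.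

Compound 4 `Cc1ccc2nc(Cl)c(/C=N/n3cc(-c4ccc(Cl)cc4)nc3N)cc2c1` differs from compound 2 by methyl in place of hydrogen on an aromatic carbon. None of the three measured steps concerns this position: all three exchange the bromo, chloro or methyl group on an aromatic carbon of a different ring, and the part of the core changed here is left untouched in every measured compound. Among the measured compounds shown here, there is therefore no measured step from which a size can be taken for this change, and with compound 2 itself sitting at a limit, the expectation is no step beyond the scatter, a step that the limit leaves unreadable from compound 2 to compound 4. Compound 4 is expected to give about 60000 nM in this assay, most likely again only a limit, within 15000 nM to 250000 nM.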

Compound 4, half-maximal inhibitory concentration: 38900 nM
Beside the measured number, compound 4's estimate is 1.5-fold (0.19 log units) above it; the measured number falls inside the stated range.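

In this assay, the shown compounds had so far varied only the bromo, chloro or methyl group on the other aromatic ring, and the step to methyl in place of hydrogen on the six-membered aromatic ring of carbon only is the first reading for this part of the shared core: an at least 1.2-fold lower number from compound 2 to compound 4 (0.10 log units; that floor lies within the scatter). Compound 4 gives a number, 38900 nM, which a chloro compound had not shown until now. Compound 2 gives only a limit, so nothing but the floor of this step can be read, and that floor lies within the scatter: the limit of > 50000 nM in this assay, at which 2 of the 4 values shown sit.

The compounds shown leave open how large the step really is and whether the same methyl would act alike in the presence of bromo or methyl on the other ring, as in the cores of compound 3 and compound 1. They also leave open what a different group on this carbon would do, such as a methoxy group, an amine, a fluoro group or a longer chain such as propyl.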